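Amino for Chloro on the Fused Ring of Compound 2

This account rests on a few compounds, and the source may have more. Where it says the series, first, only, none or still open, it means among the compounds named here.

Compounds measured so far:
compound 1, `Nc1nn(C(=O)Nc2ccc(Cc3ccccc3)cc2)c2ccccc12`, 36400 nM
compound 2, `Nc1nn(C(=O)Nc2ccc(Cc3ccccc3)cc2)c2ccc(Cl)cc12`, 33600 nM

Both compounds were tested in a functional assay on SK-MEL-2 cells (Homo sapiens) for antiproliferative activity, read by sulforhodamine B assay, with a stated time of 48 h; on this read-out lower numbers stand for stronger inhibition of growth and higher numbers for weaker inhibition of growth. Compound 1 gives 36400 nM, and compound 2 gives 33600 nM. For the measured compounds named here, the step of a 1.1-fold lower number from compound 1 to compound 2 (0.03 log units; within the scatter) is the only change measured here, and it is within the scatter. Compound 2 therefore stands at the lower of the two numbers, with compound 1 close beside it, and nothing in these two values separates them.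

Compound 3, `Nc1ccc2c(c1)c(N)nn2C(=O)Nc1ccc(Cc2ccccc2)cc1`, has not yet been measured in this assay. It differs from compound 2 by amino in place of chloro on an aromatic carbon. Going by the values given here, no measured step covers an amino group at that place; the one step that bears on the position is a 1.1-fold lower number from compound 1 to compound 2 (0.03 log units; within the scatter), which shows that the chloro group there made no difference beyond the scatter. On that basis a step of no more than the scatter is expected, in no definite direction, so the step from compound 2 to compound 3 is estimated as a 1.0-fold higher number from compound 2 to compound 3 (0.02 log units; within the scatter). Compound 3 is expected to give about 35000 nM, within a range of 15000 nM to 80000 nM.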

Compound 3, concentration for 50% growth inhibition: 26100 nM
Compound 3: the middle estimate sits 1.3-fold (0.13 log units) above what was measured; measured number inside the range.
By their numbers in this assay, from the lowest: compounds 3, 2 and 1 (each within the scatter of the next).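

In this assay, amino in place of chloro on this aromatic carbon gives a 1.3-fold lower number from compound 2 to compound 3 (0.11 log units; within the scatter), and amino in place of hydrogen at the same carbon gives a 1.4-fold lower number from compound 1 to compound 3 (0.14 log units; within the scatter). The earlier pair showed only that chloro at this place left the number within the scatter of the compound with hydrogen there; the position has now carried a second substituent, one that brings a hydrogen-bond donor and acceptor where chloro has neither, and the steps among the three compounds all remain within the scatter. No measurement is available that would explain why these numbers stay so close together.

The three compounds leave open whether any group at this carbon can move the number beyond the scatter, for instance a carboxylic acid, a nitrile, or an amine with a longer chain on its nitrogen. They also leave open whether this place would behave the same way if the rest of the core of compound 1 were altered, since all three compounds share everything outside this one position.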